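Fluorophenylsulfanyl benzamides: from compound 3 to compound 4

The source may report more compounds than this note shows. Statements on the series, on what has been measured and on what is new or still open speak of the compounds shown alone.

Of the compounds shown here, three have been measured in a functional assay on HCT-116 cells (Homo sapiens) for inhibition, read by CCK-8 assay, with a stated time of 72 h, tested at 8 uM; a lower number here means less inhibition of growth, a higher number more inhibition of growth at the concentration tested. Compound 1 `Nc1ccccc1NC(=O)c1ccc(CSc2nccc(C(F)(F)F)n2)cc1` gives 93.1%, compound 2 `Cc1cc(C)cc(SCc2ccc(/C=C/C(=O)Nc3ccccc3N)cc2)c1` gives 4.2%, and compound 3 `Nc1ccccc1NC(=O)c1ccc(CSc2cccc(F)c2)cc1` gives 81.4%. Compound 3 is the second highest of the three; compound 1 sits above it beyond the scatter, and compound 2 lies far below it, also beyond the scatter. Compound 4 `Nc1ccccc1NC(=O)c1ccc(CSc2ccc(F)cc2)cc1` is not yet measured. Its difference from compound 3 is 4-fluorophenyl in place of 3-fluorophenyl on a sulfur. For the measured compounds named here, no step between measured compounds bears on this change; the group that leaves and the group that enters carry the same atoms, joined differently. In this assay the step of a number 3.4 percentage points lower from compound 3 to compound 4 (within the scatter) is expected, within the scatter and in no firm direction. Compound 4 is estimated at 78%, with a range from 60% to 92%.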

Compound 4, percent growth inhibition at one concentration: 90.6%
Beside the measured number, compound 4's estimate is 12.6 percentage points below it, within the range that was stated.
By their numbers in this assay, from the lowest: compound 2; then compounds 3, 4 and 1 (each within the scatter of the next, the first and the last beyond it).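

For the compounds shown here, the step of a number 9.2 percentage points higher from compound 3 to compound 4 (within the scatter) in this assay is the first direct reading at this position: with the same atoms joined differently, 4-fluorophenyl in place of 3-fluorophenyl on a sulfur does not shift the number beyond the scatter. The fluorine's place on this ring can therefore change between these two options without a clear loss or gain of growth inhibition at the concentration tested. No available evidence bears on this result.

Still open, going by these compounds, is how a plain phenyl, a methoxyphenyl or a pyridyl group on the same sulfur would read against compound 4.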